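The source may report more compounds than this note shows. Statements on the series, on what has been measured and on what is new or still open speak of the compounds shown alone.

Measured so far:

- compound 1 `CCOC(=O)N(C)CC#CCN1CCCC1` — > 100 mg/kg
- compound 2 `CCOC(=O)N(C)CC#CCn1ccnc1` — 97 mg/kg
- compound 3 `CC(C#CCN1CCCC1)N1CCN(C)C1=O` — 25 mg/kg

All three were tested in a functional assay on the whole organism for antagonist activity, with Mus musculus as the target; on this read-out higher numbers stand for an effect only at larger amounts of compound and lower numbers for an effect already at smaller amounts. The value of compound 1 is a limit of the assay and not a number, as the limit of > 100 mg/kg in this assay, at which 1 of the 3 values shown sits, shows. Compound 2 differs from compound 1 by 1H-imidazol-1-yl in place of pyrrolidin-1-yl on a saturated chain carbon bound to a triple-bonded carbon, and this change produced an at least 1.0-fold lower number from compound 1 to compound 2 (0.01 log units; that floor lies within the scatter). Compound 3 has the lower of the two numbers, and its gap to compound 2 lies beyond the scatter. How the core of compound 3 differs from the core of compound 1 is not broken down here.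

Compound 4 `CC(C#CCn1ccnc1)N1CCN(C)C1=O` has not yet been measured in this assay. It differs from compound 3 by 1H-imidazol-1-yl in place of pyrrolidin-1-yl on a saturated chain carbon bound to a triple-bonded carbon, the same change at the same place as from compound 1 to compound 2. The step from compound 3 to compound 4 is expected to be a 1.1-fold lower number from compound 3 to compound 4 (0.06 log units; within the scatter), a small one, because the earlier step of an at least 1.0-fold lower number from compound 1 to compound 2 (0.01 log units; that floor lies within the scatter) stayed within the scatter. For compound 4 the estimated value is 22 mg/kg, with a likely range from 8 mg/kg to 60 mg/kg.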

Compound 4, dose for half-maximal effect: 21 mg/kg
Beside the measured number, compound 4's estimate is 1.0-fold (0.02 log units) above it; low and high end bracket the measured number.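

In this assay, placing 1H-imidazol-1-yl instead of pyrrolidin-1-yl on the core of compound 3 gives a 1.2-fold lower number from compound 3 to compound 4 (0.08 log units; within the scatter), meaning this read-out cannot tell the two compounds apart and the swap costs nothing measurable on this core. Compound 1 gives > 100 mg/kg, which is a limit of the assay and not a number. The two cores therefore show no step beyond the scatter where one can be read, but they do not show that the step keeps the same size from one core to the other: the same change on two cores in this assay, an at least 1.0-fold lower number (0.01 log units; that floor lies within the scatter) from compound 1 to compound 2 and a 1.2-fold lower number (0.08 log units; within the scatter) from compound 3 to compound 4; the limit leaves it open whether they differ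

The compounds shown leave open whether a different group at this place, such as piperidin-1-yl or a dimethylamino group, would stand apart from these two in this assay. They also leave open whether the swap would stay this small on a third core, for example one with a longer chain.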